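The source may report more compounds than this note shows. Statements on the series, on what has been measured and on what is new or still open speak of the compounds shown alone.

In a functional assay on CLL cells (Homo sapiens) for cytotoxicity, read by MTT assay, with a stated time of 48 h (a lower number here means that less compound is needed, a higher number that more compound is needed for the effect), compound 1 `C=C(CC)C(=O)c1ccc(OCC(=O)Nc2ccc(C(N)=O)cc2)c(Cl)c1Cl` gives 3700 nM. The two other compounds measured in this assay lie close to it: compound 3 `C=C(CC)C(=O)c1ccc(OCC(=O)Nc2ccc3c(c2)C(=O)NC3=O)c(Cl)c1Cl` gives 2500 nM, and compound 2 `C=C(CC)C(=O)c1ccc(OCC(=O)Nc2ccc(O)c([N+](=O)[O-])c2)c(Cl)c1Cl` gives 7400 nM. All three numbers sit within the usual scatter of one another, so compound 1 cannot be set apart from compound 3 or from compound 2 on these data; the three compounds share one core and differ only in the group carried on the amide nitrogen.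

Compound 4 `C=C(CC)C(=O)c1ccc(OCC(=O)Nc2ccc(C#N)cc2)c(Cl)c1Cl` keeps that core and changes the group on the phenyl ring: cyano in place of carbamoyl on an aromatic carbon. Within the data shown here, no measured pair shows this kind of exchange, so there is nothing to lean on beyond the three values above. Since the three measured variations of this part of the molecule all remain within the scatter of each other, the step expected from compound 1 to compound 4 is small, a 1.1-fold lower number from compound 1 to compound 4 (0.02 log units; within the scatter), in no clear direction. Compound 4 is therefore estimated at 3500 nM in this assay, with a range from 1500 nM to 8000 nM.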

Compound 4, half-maximal effective concentration: 7800 nM
Beside the measured number, compound 4's estimate is 2.2-fold (0.35 log units) below it, within the range that was stated.
By their numbers in this assay, from the lowest: compounds 3, 1, 2 and 4 (each within the scatter of the next, the first and the last beyond it).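

In this assay, cyano in place of carbamoyl on this aromatic carbon gives a 2.1-fold higher number from compound 1 to compound 4 (0.32 log units; beyond the scatter), and this is the only step shown between compounds that differ in one place. It shows that this position is not indifferent to what it carries: a modest change is seen here, where the earlier values could not be told apart, and more compound is needed with cyano than with carbamoyl. The exchange replaces a group with one hydrogen-bond donor by a group with none, but nothing measured here ties the step to that difference or to any other.

As far as these compounds go, whether an amine or a carboxylic acid on the same aromatic carbon would give a number nearer that of compound 1 or that of compound 4 remains open. So does whether a methyl group there would differ from either.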